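Phenyl for Thiophen-2-yl on Two Related Cores

The compounds below may be only part of what the source reports. "The series", "measured", "known", "first", "only" and "open" are said of these compounds alone.

Compound 1 `Cn1cccc1-c1cc(-c2cccs2)nc(N)c1C#N` and compound 2 `Cn1cccc1-c1cc(-c2cccs2)[nH]c(=O)c1C#N` are close relatives, but the difference between their two cores is not broken down here. In a functional assay on EKVX cells (Homo sapiens) for inhibition, read by sulforhodamine B assay, with a stated time of 48 h (a lower number here means a stronger inhibitor of growth, a higher number a weaker inhibitor of growth), compound 1 gives only a limit of the assay, > 100000 nM. Compound 2 gives 52500 nM in this assay. Compound 3 `Cn1cccc1-c1cc(-c2ccccc2)[nH]c(=O)c1C#N` comes from compound 2 by phenyl in place of thiophen-2-yl on an aromatic carbon. In this assay compound 3 gives 31700 nM, a step of a 1.7-fold lower number from compound 2 to compound 3 (0.22 log units; within the scatter). Compound 4 `Cn1cccc1-c1cc(-c2ccccc2)nc(N)c1C#N` comes from compound 1 by phenyl in place of thiophen-2-yl on an aromatic carbon, the same kind of change, though the surroundings differ: here the place is meta to an amino group (1 heavy atom), there meta to a group of 1 heavy atom. Because the step of a 1.7-fold lower number from compound 2 to compound 3 (0.22 log units; within the scatter) is within the scatter, a similarly small step is expected, and because the limit of > 100000 nM in this assay, at which 1 of the 3 values shown sits, places compound 1 at the limit, a limit is again likely. The expected step is a number no higher from compound 1 to compound 4 (the limit leaves the size open). Compound 4 is therefore expected to give 100000 nM, between 40000 nM and 250000 nM.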

Compound 4, concentration for 50% growth inhibition: 95500 nM
The estimate for compound 4 lay 1.0-fold (0.02 log units) above the measured number; low and high end bracket the measured number.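

In this assay, phenyl in place of thiophen-2-yl gives an at least 1.0-fold lower number from compound 1 to compound 4 (0.01 log units; that floor lies within the scatter). Carrying the change over from one core to the other can be judged only in part: the same change on two cores in this assay, a 1.7-fold lower number (0.22 log units; within the scatter) from compound 2 to compound 3 and an at least 1.0-fold lower number (0.01 log units; that floor lies within the scatter) from compound 1 to compound 4; the limit leaves it open whether they differ. The two pairs therefore show neither that the change acts alike on both cores nor that it acts differently, and they say nothing about any other core.

Still open, as far as these compounds go, is what other groups would do at this place on the ring. A cyclohexyl group in place of the phenyl, or a methoxy group or a chlorine on the phenyl, might or might not move the number beyond the scatter.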